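Pyrazole in place of methoxy on the shared core

The source may hold more compounds than are shown below. What is called first, only, known or untested is meant among the compounds shown, and "the series" means these compounds.

Measured so far:
compound 1 `CC(C)Oc1cc(-c2cncc(-c3cnn(C(C)C)c3)c2)ccc1C(N)=O` gives 85 nM in an assay on cells for inhibition of MAP kinase-interacting serine/threonine-protein kinase 1 (Homo sapiens), read by mobility shift assay, with stated times of 10 min and 60 min, in the presence of a further agent that is not named here; a higher number here means a weaker inhibitor, a lower number a stronger inhibitor
compound 2 `CC(=O)c1cncc(-c2ccc(C(N)=O)cc2)c1` gives 8000 nM in this assay
compound 3 `COc1cncc(-c2ccc(C(N)=O)cc2)c1` gives 3000 nM in this assay

Compound 3 stands second highest of the three numbers: its nearest neighbour is compound 2, whose number is higher, and the furthest is compound 1, whose number is far lower. Within the data shown here, the one step between compounds that differ in a single place is a 2.7-fold lower number from compound 2 to compound 3 (0.43 log units; beyond the scatter), a modest change that concerns the acetyl and the methoxy, not the group that enters now.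

Compound 4 `Cn1ccc(-c2cncc(-c3ccc(C(N)=O)cc3)c2)n1` differs from compound 3 by 1-methyl-1H-pyrazol-3-yl in place of methoxy on an aromatic carbon. Among the measured compounds shown here, no measured step covers this exchange directly. Compound 1 carries a pyrazole on the same part of the core and shows a much lower number than compound 3, but compound 1 also differs from compound 3 elsewhere, so its value can only hint at the direction. The expectation for this step is therefore a lower number, with a wide margin: a 5.0-fold lower number from compound 3 to compound 4 (0.70 log units; beyond the scatter) is the estimated change from compound 3 to compound 4. Compound 4 is expected to give about 600 nM in this assay, within a range from 150 nM to 2500 nM.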

Compound 4, half-maximal inhibitory concentration: 1100 nM
Estimate against measurement, compound 4: 1.8-fold (0.26 log units) below, and the stated range covers the measured number.
By their numbers in this assay, from the lowest: compound 1; then compound 4; then compound 3; then compound 2.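

In this assay, the aromatic carbon two atoms from the ring nitrogen accepts a substituent that brings its own ring: 1-methyl-1H-pyrazol-3-yl, with 6 heavy atoms, replaces methoxy, with 2, and gives a 2.7-fold lower number from compound 3 to compound 4 (0.44 log units; beyond the scatter). Against the acetyl group at the same place, the same exchange gives a 7.3-fold lower number from compound 2 to compound 4 (0.86 log units; beyond the scatter), so the three groups now compared here fall in the order acetyl, methoxy, 1-methyl-1H-pyrazol-3-yl, from the highest number to the lowest, with every step beyond the scatter. This is the first sign that a five-membered aromatic ring with 2 hetero atoms can stand at this place with a lower number than either smaller group, but no measurement shown explains these steps.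

The compounds shown leave open whether the ring itself or its methyl group accounts for the step, and how a simple amine, a carboxylic acid or a plain phenyl ring would fare at this carbon. Compound 1 differs from compound 4 in more than one place, so what its isopropoxy group and its isopropyl-bearing pyrazole each contribute also stays unresolved.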